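Closing the Alkoxy Chain into a Ring on the Core

The source may hold more compounds than are shown below. What is called first, only, known or untested is meant among the compounds shown, and "the series" means these compounds.

Compound 1 `CCCCOc1nc(C(C)(C)C)ccc1CNC(=O)C(C)c1ccc(NS(C)(=O)=O)c(F)c1`: 0.9 nM
Compound 2 `CC(C)Oc1nc(C(C)(C)C)ccc1CNC(=O)C(C)c1ccc(NS(C)(=O)=O)c(F)c1`: 2.3 nM

Both were measured in an assay on cells for antagonist activity at transient receptor potential cation channel subfamily V member 1 (Homo sapiens), read by FLIPR and calcium flux, with a stated time of 6 min; on this read-out higher numbers stand for weaker inhibition and lower numbers for stronger inhibition. Compound 2 holds the higher of the two numbers; the step is a 2.6-fold higher number from compound 1 to compound 2 (0.41 log units; beyond the scatter), a modest weakening on moving to the smaller group. Compound 3 `CC(C(=O)NCc1ccc(C(C)(C)C)nc1OC1CCCC1)c1ccc(NS(C)(=O)=O)c(F)c1` differs from compound 2 by cyclopentyl in place of isopropyl on an oxygen on an aromatic ring. Going by the values given here, only that one step bears on this change; since it went toward a smaller group and weakened inhibition, the move back to a larger group is expected to lower the number modestly. Compound 3 is expected to give 1.2 nM, between 0.5 nM and 3 nM. The expected step is a 1.9-fold lower number from compound 2 to compound 3 (0.28 log units; within the scatter).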

Compound 3, inhibition constant: 1.5 nM
Estimate against measurement, compound 3: 1.3-fold (0.10 log units) below, and the stated range covers the measured number.
By their numbers in this assay, from the lowest: compounds 1, 3 and 2 (each within the scatter of the next, the first and the last beyond it).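

Putting a ring on this oxygen keeps inhibition within the scatter of both open-chain compounds: cyclopentyl sits close to isopropyl (a 1.5-fold lower number from compound 2 to compound 3 (0.19 log units; within the scatter)) and to butyl (a 1.7-fold higher number from compound 1 to compound 3 (0.22 log units; within the scatter)). The position therefore accepts a cyclopentyl ring, and the data cannot rank that ring against either chain. Nothing available explains this result. Still open, as far as these compounds go, is how other rings on the oxygen behave, such as cyclopropyl or cyclohexyl, and whether a ring containing an oxygen atom, such as tetrahydropyranyl, fits as well.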